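Extending the urea of compound 1 into a semicarbazide

A few compounds are considered here, and "the series" means these few. Any claim that something is new, unique, unknown or untested is made for them only; others in the source may bear on it.

Measured compounds in a functional assay on MOLT-4 cells (Homo sapiens) for inhibition, read by MTT assay, with a stated time of 72 h; on this read-out lower numbers stand for stronger inhibition and higher numbers for weaker inhibition:
compound 1, `COc1cc(NC(C)CCCNC(=O)Nc2ccc(F)cc2)c2ncccc2c1`, gives 24000 nM
compound 2, `COc1cc(NC(C)CCCNC(=O)Nc2ccc(O)cc2)c2ncccc2c1`, gives 21000 nM
compound 3, `COc1cc(NC(C)CCCNC(=O)NNC(=O)Nc2cccc(C(F)(F)F)c2)c2ncccc2c1`, gives 36000 nM

All three share a common core and differ only in the tail attached to the urea nitrogen. The step of a 1.1-fold lower number from compound 1 to compound 2 (0.06 log units; within the scatter) shows that exchanging one substituent on the distal aromatic ring leaves the number essentially unchanged. Compound 1 therefore stands among three values that all lie within the scatter of one another, so none of the three can be called stronger or weaker than the others on this evidence.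

The unmeasured compound 4, `COc1cc(NC(C)CCCNC(=O)NNC(=O)Nc2ccc(F)cc2)c2ncccc2c1`, keeps the 4-fluorophenyl end of compound 1 but differs at the amide-type nitrogen: ((4-fluorophenyl)carbamoyl)amino in place of 4-fluorophenyl on an amide-type nitrogen. Among the measured compounds shown here, no measured step isolates this linker change. For the measured compounds named here, the only related information is that compound 3, which carries the same carbamoylamino linker with a different aromatic substituent, gives 36000 nM, a number within the scatter of what compound 1 gives. On this basis compound 4 is expected to remain in the same region, with a 1.3-fold higher number from compound 1 to compound 4 (0.10 log units; within the scatter) as the anticipated step, which is not beyond the scatter. The estimate for compound 4 is 30000 nM, with a range from 14000 nM to 65000 nM.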

Compound 4, half-maximal inhibitory concentration: >= 250000 nM
Compound 4: only a limit was reported (the forecaster's own chance of this, stated with the estimate: 15%); middle value at least 8.3-fold (0.92 log units) away from the limit.
By their numbers in this assay, from the lowest: compounds 2, 1 and 3 (each within the scatter of the next). At a limit, above all of these: compound 4.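

In this assay compound 4 is reported only as a limit of the assay, and it alone among the compounds shown sits there: the limit of >= 250000 nM in this assay, at which 1 of the 4 values shown sits. Placing ((4-fluorophenyl)carbamoyl)amino on the amide-type nitrogen gives an at least 10-fold higher number from compound 1 to compound 4 (1.01 log units; beyond the scatter), and the change from the 4-hydroxyphenyl end gives an at least 11-fold higher number from compound 2 to compound 4 (1.07 log units; beyond the scatter), so at this position the extended tail carries a cost that the earlier compounds, all within the scatter of one another, gave no sign of. The extended linker does not settle the outcome alone, since 4-fluorophenyl in place of 3-(trifluoromethyl)phenyl on the same kind of nitrogen gives an at least 6.9-fold higher number from compound 3 to compound 4 (0.84 log units; beyond the scatter), which shows that the aromatic end matters on this tail, whereas the exchange on the shorter urea tail stayed within the scatter.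

On these data alone, with only two aromatic ends on the extended tail, it remains open which feature of 3-(trifluoromethyl)phenyl separates compound 3 from compound 4, and whether a chlorine or an amine on that ring would fall with either of them. As far as these compounds go, it also remains open how a longer chain in the tail would behave, and the limit leaves the true size of these steps unknown.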